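Compound 3 to compound 4: bromo for trifluoromethyl

A few compounds are considered here, and "the series" means these few. Any claim that something is new, unique, unknown or untested is made for them only; others in the source may bear on it.

Measured in an ADME assay on HeLa cells (Homo sapiens) for cytotoxicity, read by resazurin assay, with a stated time of 65 h; on this read-out lower numbers stand for an effect already at smaller amounts and higher numbers for an effect only at larger amounts of compound
- compound 1 `CCc1cc(C(=O)O)c(NC(=O)c2ccc([N+](=O)[O-])o2)s1` gives > 20000 nM as a limit
- compound 2 `O=C(Nc1ccccc1)c1ccc([N+](=O)[O-])o1` gives > 20000 nM as a limit
- compound 3 `O=C(Nc1cccc(C(F)(F)F)c1)c1ccc([N+](=O)[O-])o1` gives > 20000 nM as a limit

Compound 3 stands at > 20000 nM, which is a limit of the assay and not a number. Going by the values given here, the other two values are limits as well, so the whole picture is the limit of > 20000 nM in this assay, at which 3 of the 3 values shown sit, and no compound can be ranked against another.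

Compound 4 `O=C(Nc1cccc(Br)c1)c1ccc([N+](=O)[O-])o1` differs from compound 3 in one place (bromo in place of trifluoromethyl on an aromatic carbon), with bromo in place of trifluoromethyl on an aromatic carbon, meta to a large group.

Among the compounds with values here, the only measured step that bears on this change is a step that the two limits leave unreadable from compound 2 to compound 3, and it gives no size to carry over. It does show that trifluoromethyl in place of hydrogen left the read-out at the same limit. No step beyond the usual scatter is therefore expected in this assay, and no direction can be assigned. A further limit is the most likely report for compound 4.

The expected step is a number no higher from compound 3 to compound 4 (the limit leaves the size open) on this estimate. For compound 4 the estimated value is 20000 nM, with an expected range from 8000 nM to 40000 nM in this assay.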

Compound 4, half-maximal effective concentration: > 20000 nM
Compound 4: a limit, no number; the forecaster's own chance of this, stated with the estimate: 75%; the middle value lies on the limit itself.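

In this assay compound 4 gives > 20000 nM as a limit of the assay and not a number.
No step between compound 2, compound 3 and compound 4 can be read, because all values shown sit at one limit: the limit of > 20000 nM in this assay, at which 4 of the 4 values shown sit.
The compounds shown leave open which change to the shared core, if any, would give a measurable number in this assay for this series.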